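The compounds below may be only part of what the source reports. "The series", "measured", "known", "first", "only" and "open" are said of these compounds alone.

Compound 1 `O=C1C=CC(OCC(F)(F)F)N1c1ccccc1` was examined in a functional assay on HeLa cells (Homo sapiens) for inhibition; a lower number here means a stronger inhibitor, a higher number a weaker inhibitor. In this assay compound 1 gives only > 100000 nM, a limit of the assay rather than a number. Compound 2 `O=C1C=CC(OCC(F)(F)F)N1c1ccc([N+](=O)[O-])cc1` carries a nitro group, and in this assay compound 2 gives 2380 nM. That change brought an at least 42-fold lower number from compound 1 to compound 2 (1.62 log units; beyond the scatter). Compound 3 `O=C1C=CC(OCC(F)(F)F)N1c1ccccc1F` differs from compound 1 by fluoro in place of hydrogen on an aromatic carbon. Among the compounds with values here, the only measured step that bears on this concerned a nitro group and was large; a fluoro group is a different group, so a smaller step, if any, is expected, with compound 1 sitting at the limit of > 100000 nM in this assay, at which 1 of the 2 values shown sits. The step of an at least 1.4-fold lower number from compound 1 to compound 3 (0.15 log units; that floor lies within the scatter) is expected to be modest. Compound 3 is estimated at 70000 nM, between 10000 nM and 300000 nM.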

Compound 3, half-maximal inhibitory concentration: 19300 nM
The estimate for compound 3 lay 3.6-fold (0.56 log units) above the measured number; the measured number falls inside the stated range.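

In this assay, fluoro in place of hydrogen on an aromatic carbon, ortho to a large group, brought an at least 5.1-fold lower number from compound 1 to compound 3 (0.71 log units; beyond the scatter). A step beyond the scatter on this aromatic ring is therefore not confined to the nitro group of compound 2, and a single fluoro group at this place is enough to produce one. The true size of the step remains unknown because compound 1 stands at a limit of the assay: the limit of > 100000 nM in this assay, at which 1 of the 3 values shown sits.

Going by these compounds, it remains open whether fluoro on another carbon of the aromatic ring would lower the number as well. On these data alone, it also remains open how an amine or a carboxylic acid at this same place would compare with fluoro.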